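The source may hold more compounds than are shown below. What is called first, only, known or untested is meant among the compounds shown, and "the series" means these compounds.

Going by the values given here, in a functional assay on HeLa cells (Homo sapiens) for cytotoxicity (on this read-out lower numbers stand for stronger inhibition and higher numbers for weaker inhibition), compound 1 (`CCCOC1=CC(=O)c2ccccc2C1=O`) gives 51600 nM and holds the higher of the two numbers so far, which means weaker inhibition than compound 2 (`Cc1ccc(S(=O)(=O)Oc2ccc3c(c2)C(=O)C=CC3=O)cc1`) with 15100 nM on this read-out. Compared with compound 1, compound 3 (`CC(=O)OC1=CC(=O)c2ccccc2C1=O`) carries acetyl in place of propyl on an oxygen on an unsaturated carbon. Among the compounds with values here, no measured pair shows this change, so the expectation is loose: a modest drop toward stronger inhibition, slightly beyond the scatter, with an estimated 2.6-fold lower number from compound 1 to compound 3 (0.41 log units; beyond the scatter) as the step. Compound 3 is expected at 20000 nM with 6000 nM to 60000 nM as the estimated range.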

Compound 3, half-maximal inhibitory concentration: 62100 nM
For compound 3 the middle estimate is 3.1-fold (0.49 log units) below the measured one; the whole stated range lies below it.
By their numbers in this assay, from the lowest: compound 2; then compounds 1 and 3 (each within the scatter of the next).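

In this assay the change from propoxy to acetoxy on the shared core amounts to a 1.2-fold higher number from compound 1 to compound 3 (0.08 log units; within the scatter) and so leaves the read-out unmoved. At this oxygen, then, a propyl and an acetyl cannot be told apart, even though the acetyl brings a double bond outside aromatic rings and a hydrogen-bond acceptor that the propyl lacks. No measurement at hand explains this result. Going by these compounds, whether a longer chain, an amine or a carboxylic acid on this oxygen would shift the number remains open.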